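Aryl Imine Swap on the Shared Core: Expected Cytotoxicity

This account rests on a few compounds, and the source may have more. Where it says the series, first, only, none or still open, it means among the compounds named here.

Compound 1, `O=C1Nc2ccc(S(=O)(=O)N3CCOCC3)cc2/C1=N/NC(=O)c1ccccc1`, is the starting point of this account. For the measured compounds named here, in an ADME assay on WI-38 cells (Homo sapiens) for cytotoxicity, read by sulforhodamine B assay, with a stated time of 24 h (a higher number here means a weaker inhibitor, a lower number a stronger inhibitor), compound 1 gives 295000 nM, the second highest of the three numbers measured so far. Its nearest neighbour is compound 2, `O=C1Nc2ccc(S(=O)(=O)N3CCOCC3)cc2/C1=N/NS(=O)(=O)c1ccccc1`, which in this assay gives 302000 nM; the furthest is compound 3, `O=C1Nc2ccc(S(=O)(=O)N3CCOCC3)cc2/C1=N/c1cccc(C(F)(F)F)c1`, which in this assay gives 226000 nM. The step of a 1.0-fold higher number from compound 1 to compound 2 (0.01 log units; within the scatter) arises from phenylsulfonyl in place of benzoyl on an amine nitrogen, and the step of a 1.3-fold lower number from compound 1 to compound 3 (0.12 log units; within the scatter) from 3-(trifluoromethyl)phenyl in place of benzamido on a double-bonded nitrogen. The step of a 1.3-fold lower number from compound 2 to compound 3 (0.13 log units; within the scatter) comes from 3-(trifluoromethyl)phenyl in place of (phenylsulfonyl)amino on a double-bonded nitrogen. All three steps stay within the scatter.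

Compound 4, `CC(=O)c1cccc(/N=C2\C(=O)Nc3ccc(S(=O)(=O)N4CCOCC4)cc32)c1`, has not yet been measured. It differs from compound 1 as follows: 3-acetylphenyl in place of benzamido on a double-bonded nitrogen. Going by the values given here, the closest precedent is a 1.3-fold lower number from compound 1 to compound 3 (0.12 log units; within the scatter), where a substituted phenyl likewise replaced benzamido on a double-bonded nitrogen. Because the step of a 1.3-fold lower number from compound 1 to compound 3 (0.12 log units; within the scatter) lay within the scatter and the two other steps did the same, no movement beyond the scatter is expected for compound 4 in this assay, and the expected step is a 1.2-fold lower number from compound 1 to compound 4 (0.07 log units; within the scatter). Compound 4 is therefore estimated at 250000 nM, with a range from 150000 nM to 420000 nM.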

Compound 4, half-maximal inhibitory concentration: 177000 nM
Compound 4: middle estimate off by 1.4-fold (0.15 log units), on the high side, within the range that was stated.
By their numbers in this assay, from the lowest: compounds 4, 3, 1 and 2 (each within the scatter of the next).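

In this assay, the step of a 1.3-fold lower number from compound 3 to compound 4 (0.11 log units; within the scatter) is the only one among these compounds that keeps a substituted phenyl on the double-bonded nitrogen and alters just the group on its aromatic carbon, and it shows that acetyl and trifluoromethyl cannot be told apart there. The steps of a 1.7-fold lower number from compound 1 to compound 4 (0.22 log units; within the scatter) and a 1.7-fold lower number from compound 2 to compound 4 (0.23 log units; within the scatter) are wider than those seen before, yet both remain within the scatter, so 3-acetylphenyl, which has no hydrogen-bond donor, is not separated from benzamido, which has one, or from (phenylsulfonyl)amino on that nitrogen. No measurement bearing on why these numbers fall as they do is available here.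

The compounds shown leave open whether an amine or a carboxylic acid in place of acetyl on the aromatic carbon, or a longer chain in place of the acetyl group, would carry the number beyond the scatter. They also leave open whether any change to the shared core itself would matter in this assay, as all four compounds carry it unchanged.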